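A few compounds are considered here, and "the series" means these few. Any claim that something is new, unique, unknown or untested is made for them only; others in the source may bear on it.

Compound 3 `O=C(NO)c1ccc(-c2cn([C@H]3C[C@H](C(=O)O)N(Cc4ccccc4)C3)nn2)cc1` was examined in an assay on Sf9 cells for inhibition of histone deacetylase 11 (Homo sapiens), read by fluorescence, tested at 0.5 uM; a lower number here means less inhibition, a higher number more inhibition at the concentration tested (going by the name of the read-out). In this assay compound 3 gives < 10%, which is a limit of the assay rather than a number. Its two stereoisomeric relatives that carry a hydroxymethyl in place of the carboxy, compound 1 `O=C(NO)c1ccc(-c2cn([C@H]3C[C@@H](CO)N(Cc4ccccc4)C3)nn2)cc1` and compound 2 `O=C(NO)c1ccc(-c2cn([C@@H]3C[C@@H](CO)N(Cc4ccccc4)C3)nn2)cc1`, stand no differently. In this assay compound 1 gives < 10%, a limit. In this assay compound 2 gives < 10%, also a limit. The step that the two limits leave unreadable from compound 1 to compound 2 cannot be read because of the limit of < 10% in this assay, at which 3 of the 3 values shown sit, even though the fact that compounds 1 and 2 differ only in the configuration as drawn shows how little separates the pair. The untested member is compound 4 `O=C(NO)c1ccc(-c2cn([C@H]3C[C@H](CO)N(Cc4ccccc4)C3)nn2)cc1`, which differs from compound 3 in one place: hydroxymethyl in place of carboxy on a saturated ring carbon. Since every measured value rests on a limit and no readable step exists, the change from compound 3 is expected to leave the read-out where it is, and the step that the limit leaves unreadable from compound 3 to compound 4 is expected to fall within the scatter. Compound 4 is therefore estimated at 5% in this assay, with a range from 0% to 12%.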

Compound 4, a percentage reported as inhibition, at one concentration (the size of the read-out at that concentration, not a potency): 16%
Compound 4: middle estimate off by 11 percentage points, on the low side; measured number outside the range, above it.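

Among the compounds shown here, compound 4 is the only compound here to give a number rather than a limit in this assay, so a read-out above the limit is possible with hydroxymethyl on this saturated ring carbon. Hydroxymethyl in place of carboxy gives a number at least 6 percentage points higher from compound 3 to compound 4 (that floor lies within the scatter), while configuration alone gives a number at least 6 percentage points higher from compound 1 to compound 4 (that floor lies within the scatter) and a number at least 6 percentage points higher from compound 2 to compound 4 (that floor lies within the scatter), and each of these floors lies within the scatter, so none of them establishes a real gain. The steps among the other compounds cannot be read, for one reason: the limit of < 10% in this assay, at which 3 of the 4 values shown sit.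

Going by these compounds, the true size of each step stays open, as does whether either change is what lifts compound 4. On these data alone, how an amine, a methyl ester or a longer chain would read on this ring carbon also stays open.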